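A few compounds are considered here, and "the series" means these few. Any claim that something is new, unique, unknown or untested is made for them only; others in the source may bear on it.

Three members of the series have numbers in a functional assay on NCI-H460 cells (Homo sapiens) for antiproliferative activity, read by CCK-8 assay, with a stated time of 72 h, tested at 8 uM; a lower number here means a weaker effect, a higher number a stronger effect of the compound at the concentration tested. Compound 1 `COC(CCn1cnc2c(NCc3ccc(C(=O)Nc4ccccc4N)cc3)nc(Cl)nc21)OC` gives 51.2% in this assay. Compound 2 `Cc1ccc(Nc2nc(Cl)nc3c2ncn3Cc2ccc(C(=O)Nc3ccccc3N)cc2)cc1` gives 82.5% in this assay. Compound 3 `CC1CCN(c2nc(Cl)nc3c2ncn3Cc2ccc(/C=C/C(=O)Nc3ccccc3N)cc2)CC1` gives 10.8% in this assay, the lowest of the three numbers; compound 1 stands nearest to it, with a number higher by an amount beyond the scatter, and compound 2 stands furthest, with a number higher by an amount also beyond the scatter.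

Compound 4 `Cc1ccc(Nc2nc(Cl)nc3c2ncn3Cc2ccc(/C=C/C(=O)Nc3ccccc3N)cc2)cc1` has not yet been measured in this assay. It differs from compound 3 in a single place: (4-methylphenyl)amino in place of 4-methylpiperidin-1-yl on an aromatic carbon. The rest of compound 3 is kept. Among the compounds with values here, no pair of measured compounds differs in only one place, so no measured step is at hand to set the size of this change. Within the data shown here, what can be said is that compound 2, the one measured compound carrying the entering group, gives 82.5% in this assay, while compound 4 and compound 2 differ in a part of the molecule for which no measured pair exists.

On that basis an upward step is expected for compound 4, estimated as a number 44.2 percentage points higher from compound 3 to compound 4 (beyond the scatter), beyond the scatter. The expected value for compound 4 in this assay is 55%, with a range from 20% to 85%.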

Compound 4, a percentage reported as inhibition, at one concentration (the size of the read-out at that concentration, not a potency): 51.3%
Beside the measured number, compound 4's estimate is 3.7 percentage points above it; the range from low to high includes it.
By their numbers in this assay, from the lowest: compound 3; then compounds 1 and 4 (each within the scatter of the next); then compound 2.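

In this assay, within the data shown here, the exchange of 4-methylpiperidin-1-yl for (4-methylphenyl)amino on the aromatic carbon of the core gives a number 40.5 percentage points higher from compound 3 to compound 4 (beyond the scatter), the first single-place reading at this position, and it shows that the number depends strongly on the group held there when the 2-((2-aminophenyl)carbamoyl)ethenyl group is present. With (4-methylphenyl)amino held fixed, the other end of the molecule can now be read as well: 2-((2-aminophenyl)carbamoyl)ethenyl in place of (2-aminophenyl)carbamoyl gives a number 31.2 percentage points lower from compound 2 to compound 4 (beyond the scatter), so that part of the molecule also moves the number in this assay by a large step, though this rests on a single pair. Nothing in hand bears on the reason for either step.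

The step at this position combines a change of ring with the gain of the amino link, and a cyclohexylamino group or a 4-methylphenyl group joined directly to the core would be needed to read these two parts separately. On these data alone, whether the size of the step carries over to compounds with (2-aminophenyl)carbamoyl remains open, since 4-methylpiperidin-1-yl appears here only with the ethenyl-containing group.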